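Acetyl for methylsulfonyl: a solubility step from compound 2

The source may report more compounds than this note shows. Statements on the series, on what has been measured and on what is new or still open speak of the compounds shown alone.

Of the compounds shown here, three have been measured in a physicochemical assay for solubility, read by nephelometry, measured as kinetic solubility, at pH 6.5; a lower number here means a less soluble compound, a higher number a more soluble compound. Compound 1 `CC(C)(C)c1cc(C(=O)Nc2ccccn2)n(Cc2ccccc2)n1` gives 6.3 ug/mL in this assay. Compound 3 `NCc1csc(NC(=O)c2cccnn2)n1` gives 50 ug/mL. Compound 2 `CC(C)(C)c1cc(C(=O)Nc2nc(CNS(C)(=O)=O)cs2)n(Cc2ccccc2)n1` gives 3.1 ug/mL, the lowest of the three numbers, lying beyond the scatter below both compound 1 and compound 3. The next compound, compound 4 `CC(=O)NCc1csc(NC(=O)c2cc(C(C)(C)C)nn2Cc2ccccc2)n1`, is not yet measured. It differs from compound 2 in one place: acetyl in place of methylsulfonyl on an amine nitrogen. Within the data shown here, no measured pair shows this change. Among the measured compounds shown here, since nothing among the measured compounds speaks for a large shift, the step from compound 2 to compound 4 is expected to stay within the scatter, as a 1.1-fold higher number from compound 2 to compound 4 (0.05 log units; within the scatter). Compound 4 is therefore estimated at 3.5 ug/mL in this assay, with a range from 1.2 ug/mL to 10 ug/mL.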

Compound 4, solubility: 12.5 ug/mL
Compound 4: the middle estimate sits 3.6-fold (0.55 log units) below what was measured; measured number above the stated range.
By their numbers in this assay, from the lowest: compound 2; then compounds 1 and 4 (each within the scatter of the next); then compound 3.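

In this assay, the exchange of methylsulfonyl for acetyl on this amine nitrogen is not a neutral one: it gives a 4.0-fold higher number from compound 2 to compound 4 (0.61 log units; beyond the scatter) and is a modest step, yet beyond the scatter. Among these compounds, this is the first measured pair to show that a change at this position alone can move the number. Nothing measured here indicates what lies behind the step. Going by these compounds, whether a longer acyl chain or a carboxylic acid in place of acetyl would shift the number further remains open, as does whether the same exchange would give a similar step on another core.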